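Two Bis-Sulfonylbenzenes Measured, a Dipropylamino Analogue Estimated

The compounds below may be only part of what the source reports. "The series", "measured", "known", "first", "only" and "open" are said of these compounds alone.

Compound 1 `CCOC(=O)[C@@H]1CCCN(S(=O)(=O)c2ccc(S(=O)(=O)N3CCCCC3)cc2)C1`: 3300 nM
Compound 2 `CCN(CC)S(=O)(=O)c1ccc(S(=O)(=O)N2CCC[C@@H](c3nc(C)no3)C2)cc1`: 2900 nM

In a functional assay on BXPC-3 cells (Homo sapiens) for inhibition, read by MTT assay, with a stated time of 7 days (a lower number here means a stronger inhibitor, a higher number a weaker inhibitor), compound 1 gives 3300 nM, the higher of the two numbers recorded, while compound 2 gives 2900 nM; the two values lie within the scatter of each other, so neither can be called the stronger. Compound 3 `CCCN(CCC)S(=O)(=O)c1ccc(S(=O)(=O)N2CCC[C@@H](C(=O)OCC)C2)cc1` differs from compound 1 in one place: dipropylamino in place of piperidin-1-yl on a sulfonyl sulfur. Among the measured compounds shown here, no measured pair shows this change, so the step from compound 1 to compound 3 can only be guessed; it is expected to stay within the scatter, a 1.1-fold lower number from compound 1 to compound 3 (0.04 log units; within the scatter). Compound 3 is therefore estimated at 3000 nM, with a range from 1000 nM to 9000 nM.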

Compound 3, half-maximal inhibitory concentration: 2500 nM
Estimate against measurement, compound 3: 1.2-fold (0.08 log units) above; the range from low to high includes it.
By their numbers in this assay, from the lowest: compounds 3, 2 and 1 (each within the scatter of the next).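

In this assay dipropylamino, which has no ring, takes the place of piperidin-1-yl on a sulfonyl sulfur, giving a 1.3-fold lower number from compound 1 to compound 3 (0.12 log units; within the scatter). This first measured pair shows that, in this one case, exchanging the ring for two propyl chains leaves the number within the scatter. Nothing at hand bears on the reason for this result. As far as these compounds go, whether a shorter dimethylamino group or morpholin-4-yl at this place would also leave the number unmoved remains open. So does the effect of a carboxylic acid in place of the ethyl ester.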